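A few compounds are considered here, and "the series" means these few. Any claim that something is new, unique, unknown or untested is made for them only; others in the source may bear on it.

Measured so far:
- compound 1, `CCOC(=O)c1ccc(NC(=O)NCc2cc[nH]n2)cc1`: 69000 nM
- compound 2, `O=C(NCc1ccncc1)Nc1ccc(S(=O)(=O)NCc2ccccc2)cc1`: 102 nM
- compound 3, `CCOC(=O)c1ccc(NC(=O)N(C)Cc2ccncc2)cc1`: > 100000 nM

These three compounds share a urea core and were tested in an assay on isolated protein for activation of Nicotinamide phosphoribosyltransferase (Homo sapiens); on this read-out higher numbers stand for an effect only at larger amounts of compound and lower numbers for an effect already at smaller amounts. Compound 1 gives 69000 nM. Compound 2 gives 102 nM, the lowest of the two numbers that were reported, and its gap to compound 1 lies well beyond the usual scatter. For compound 3 the assay reports only a limit, > 100000 nM, and not a number; (the limit of > 100000 nM in this assay, at which 1 of the 3 values shown sits).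

The next compound to be measured is compound 4, `CCN(CC)S(=O)(=O)c1ccc(NC(=O)NCc2ccncc2)cc1`. It differs from compound 2 in one place: diethylamino in place of benzylamino on a sulfonyl sulfur. Going by the values given here, no pair of the measured compounds differs in exactly this way, so the size of the step has no direct precedent among them; the benzylamino group of compound 2 is the only sulfonamide substituent for which a number is known.

The expectation for compound 4 is a moderate weakening, a step from compound 2 of about a 2.9-fold higher number from compound 2 to compound 4 (0.47 log units; beyond the scatter) in this assay, reaching beyond the scatter but by no means as large as the gap to compound 1. Compound 4 is therefore estimated at 300 nM, within a range from 80 nM to 1500 nM.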

Compound 4, half-maximal effective concentration: 384 nM
Compound 4: the middle estimate sits 1.3-fold (0.11 log units) below what was measured; the range from low to high includes it.
By their numbers in this assay, from the lowest: compound 2; then compound 4; then compound 1. At a limit, above all of these: compound 3.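

In this assay, going by these compounds alone, putting diethylamino in place of benzylamino on a sulfonyl sulfur gives a 3.8-fold higher number from compound 2 to compound 4 (0.58 log units; beyond the scatter) and counts as a modest step, the first reading of what a change at this spot costs. The swap takes away a six-membered aromatic ring of carbon only and a hydrogen-bond donor, and shortens the group from eight heavy atoms to five, yet compound 4 still gives a measured number of 384 nM and not a limit, so neither the ring nor the donor of benzylamino is needed for an effect on this read-out. The ring and the donor leave together, which means their shares in the step cannot be told apart, and nothing measured here gives a reason for its size.

A benzyl(methyl)amino group on the same sulfur, which keeps the ring and drops the donor, would pull these two apart. As far as these compounds go, it also remains open whether a smaller dimethylamino group or a morpholine ring would land nearer to compound 2 or to compound 4, so the trend rests on this single pair.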